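The compounds below may be only part of what the source reports. "The series", "measured", "known", "first", "only" and "open" are said of these compounds alone.

Measured compounds in an in vitro functional assay on HEK285-7 cells for antagonist activity at prostaglandin D2 receptor 2 (Homo sapiens), read by BRET and beta-arrestin recruitment; a lower number here means a smaller maximal response, a higher number a larger maximal response:
compound 1 `O=C(O)Cc1sc(C(c2ccccc2)c2ccc(Cl)cc2)nc1-c1ccc(Cl)cc1` — 80%
compound 2 `CCC(c1ccccc1)c1nc(-c2ccc(Cl)cc2)c(CC(=O)O)s1` — 50%
compound 3 `O=C(O)Cc1sc(C(c2ccccc2)c2ccc(F)cc2)nc1-c1ccc(Cl)cc1` — 80%

Compound 3 stands at the top of these three numbers together with compound 1, the two being within the scatter of each other: no change at the digits printed from compound 1 to compound 3 (within the scatter). Against compound 2 the picture is clearer, as a number 30 percentage points higher from compound 2 to compound 3 (beyond the scatter).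

Compound 4 `O=C(O)Cc1sc(C(Cc2ccccc2)c2ccccc2)nc1-c1ccc(Cl)cc1` is the next step from compound 3. The change is benzyl in place of 4-fluorophenyl on a saturated chain carbon bound to two aromatic carbons. Within the data shown here, two measured steps bear on it, both at the same saturated chain carbon: a number 30 percentage points lower from compound 1 to compound 2 (beyond the scatter), and in the reverse sense a number 30 percentage points higher from compound 2 to compound 3 (beyond the scatter). Removing an aromatic ring from that carbon in favour of a short chain cost a modest, reproducible amount of maximal response. Benzyl keeps a six-membered aromatic ring but moves it out by one carbon, so a smaller loss than the ethyl case is expected, possibly none beyond the scatter.

Compound 4 is therefore expected to give 65%, within 45% to 85%. The estimated step is a number 15 percentage points lower from compound 3 to compound 4 (beyond the scatter).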

Compound 4, largest response reached (reported as efficacy), in percent of the reference or control that the assay uses: 50%
For compound 4 the middle estimate is 15 percentage points above the measured one, within the range that was stated.
By their numbers in this assay, from the lowest: compounds 2 and 4 (each within the scatter of the next); then compounds 1 and 3 (each within the scatter of the next).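

In this assay the benzyl group at the saturated chain carbon bound to two aromatic carbons did not keep the higher response: there is a number 30 percentage points lower from compound 3 to compound 4 (beyond the scatter) and a number 30 percentage points lower from compound 1 to compound 4 (beyond the scatter) for the change from an aryl group on that carbon. Ethyl and benzyl do not separate, with no change at the digits printed from compound 2 to compound 4 (within the scatter) here, so keeping a six-membered aromatic ring on the chain was not enough. Among these four compounds, the higher numbers appear only where 4-chlorophenyl or 4-fluorophenyl sits on that carbon, and nothing measured here gives a reason for this.

From the compounds shown here alone, it remains open whether a longer chain such as 2-phenylethyl would behave like benzyl and ethyl. Going by these compounds, it is equally open whether a 4-methoxyphenyl group or a pyridine ring on that carbon would match the halogenated rings.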